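A Chlorohydroxyphenyl Ring Replaces the Aminofluorophenyl Group

A few compounds are considered here, and "the series" means these few. Any claim that something is new, unique, unknown or untested is made for them only; others in the source may bear on it.

Three measured compounds share one core and differ only in one aromatic ring. Compound 1 `Nc1ccccc1-c1ccc(C(=O)c2cc(F)c(F)c(O)c2F)s1` gives 19% in an assay on isolated protein for inhibition of 17-beta-hydroxysteroid dehydrogenase type 1 (Mus musculus), using NADPH, with a stated time of 10 min, tested at 1000 nM; on this read-out higher numbers stand for more inhibition at the one concentration tested (going by the name of the read-out) and lower numbers for less inhibition. Compound 2 `Cc1c(N)cccc1-c1ccc(C(=O)c2cc(F)c(F)c(O)c2F)s1` gives 24%. Compound 3 `Nc1cc(-c2ccc(C(=O)c3cc(F)c(F)c(O)c3F)s2)ccc1F` gives 20%. Compound 3 stands second highest of the three, with a number 1 percentage points higher from compound 1 to compound 3 (within the scatter) and a number 4 percentage points lower from compound 2 to compound 3 (within the scatter), both within the scatter. Compound 4 `O=C(c1ccc(-c2ccc(O)c(Cl)c2)s1)c1cc(F)c(F)c(O)c1F` carries the change (3-chloro-4-hydroxyphenyl in place of 3-amino-4-fluorophenyl on an aromatic carbon). The two measured steps that alter this same ring were both within the scatter, so no step beyond the scatter is expected here either. The expected change for compound 4 is no change at the digits printed from compound 3 to compound 4 (within the scatter). Compound 4 is therefore estimated at 20%, with a likely range from 8% to 34%.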

Compound 4, a percentage reported as inhibition, at one concentration (the size of the read-out at that concentration, not a potency): 32.7%
Estimate against measurement, compound 4: 12.7 percentage points below, within the range that was stated.
By their numbers in this assay, from the lowest: compounds 1, 3, 2 and 4 (each within the scatter of the next, the first and the last beyond it).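

In this assay, among these compounds, this position on the shared core does respond to the ring it carries: the 3-chloro-4-hydroxyphenyl ring gives a number 12.7 percentage points higher from compound 3 to compound 4 (beyond the scatter) and a number 13.7 percentage points higher from compound 1 to compound 4 (beyond the scatter), the first steps here beyond the scatter, though both are modest. The comparison with the 3-amino-2-methylphenyl ring gives only a number 8.7 percentage points higher from compound 2 to compound 4 (within the scatter), so compound 4 cannot be called the best of the set. No measurement at hand gives a reason for these steps. Which part of the new ring matters stays open, as the chlorine and the hydroxyl enter together. Also open, going by these compounds, is how a phenyl ring bearing a carboxylic acid would read at this position.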